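Swapping the carbamoyl side chain for a small ester-free group

The source may report more compounds than this note shows. Statements on the series, on what has been measured and on what is new or still open speak of the compounds shown alone.

Three compounds have been measured in a functional assay on HCT-116 cells (Homo sapiens) for antiproliferative activity, read by MTT assay, with a stated time of 72 h; on this read-out higher numbers stand for weaker inhibition and lower numbers for stronger inhibition:
compound 1 `CCN(CC)CCNC(=O)Nc1nc2ccc(-c3cnc(OC)c(NS(=O)(=O)c4ccc(F)cc4)c3)cc2s1` gives 300 nM
compound 2 `COc1ncc(-c2ccc3nc(NC4CC4)sc3c2)cc1NS(=O)(=O)c1ccc(F)cc1` gives 1560 nM
compound 3 `COc1ncc(-c2ccc3nc(NC(=O)NCCN4CCCCC4)sc3c2)cc1NS(=O)(=O)c1ccc(F)cc1` gives 610 nM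

Compound 3 holds the second highest number of the three. Its nearest neighbour is compound 1, and the step between them is a 2.0-fold higher number from compound 1 to compound 3 (0.31 log units; beyond the scatter); its furthest is compound 2, with a 2.6-fold lower number from compound 2 to compound 3 (0.41 log units; beyond the scatter).

Compound 4 `CCOC(=O)CNc1nc2ccc(-c3cnc(OC)c(NS(=O)(=O)c4ccc(F)cc4)c3)cc2s1` differs from compound 3 in one place: (ethoxycarbonyl)methyl in place of (2-(piperidin-1-yl)ethyl)carbamoyl on a nitrogen on an aromatic ring. Going by the values given here, two measured steps bear on this, since both change the same nitrogen on an aromatic ring between a (2-(...)ethyl)carbamoyl group and a small group: a 5.2-fold higher number from compound 1 to compound 2 (0.72 log units; beyond the scatter) and a 2.6-fold lower number from compound 2 to compound 3 (0.41 log units; beyond the scatter). In both, losing the carbamoyl side chain went with a higher number, so for compound 4 a higher number than for compound 3 is expected, of a size near those steps, as a 2.3-fold higher number from compound 3 to compound 4 (0.36 log units; beyond the scatter). Compound 4 is therefore estimated at 1400 nM, with a range from 450 nM to 4500 nM.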

Compound 4, half-maximal inhibitory concentration: > 20000 nM
Compound 4: a limit, no number; the forecaster's own chance of this, stated with the estimate: 3%; at least 14-fold (1.15 log units) between middle value and limit.
By their numbers in this assay, from the lowest: compound 1; then compound 3; then compound 2. At a limit, above all of these: compound 4.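

In this assay compound 4 gives > 20000 nM, which is a limit of the assay and not a number. Going by these compounds alone, at this nitrogen on an aromatic ring, the change to (ethoxycarbonyl)methyl gives much larger steps than any seen among the earlier compounds: an at least 32-fold higher number from compound 3 to compound 4 (1.51 log units; beyond the scatter) and an at least 66-fold higher number from compound 1 to compound 4 (1.82 log units; beyond the scatter), and even against the cyclopropyl group there is an at least 12-fold higher number from compound 2 to compound 4 (1.10 log units; beyond the scatter). Losing the carbamoyl side chain therefore does not set the outcome by itself, as compound 2 also lacks that chain and still gives 1560 nM.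

As far as these compounds go, the true size of these steps stays open, as does whether the ester matters or the chain that carries it. A carboxylic acid in place of the ethyl ester, or a plain propyl chain on the same nitrogen, would help separate those two.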